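This account rests on a few compounds, and the source may have more. Where it says the series, first, only, none or still open, it means among the compounds named here.

In a functional assay on K562 cells (Homo sapiens) for antiproliferative activity, with a stated time of 72 h (a lower number here means a stronger inhibitor, a higher number a weaker inhibitor), compound 2 `OC[C@H]1O[C@@H](n2cnc3c(NCc4ccc(F)c(Cl)c4)ncnc32)[C@H](O)[C@@H]1O` gives 5500 nM, within the scatter of compound 1 `OC[C@H]1O[C@@H](n2cnc3c(NCc4ccccc4Br)ncnc32)[C@H](O)[C@@H]1O` at 10000 nM. Compound 3 `Cc1cccc(CNc2ncnc3c2ncn3[C@@H]2O[C@H](CO)[C@@H](O)[C@H]2O)c1O` carries 2-hydroxy-3-methylphenyl in place of 3-chloro-4-fluorophenyl on the same saturated chain carbon: 2-hydroxy-3-methylphenyl in place of 3-chloro-4-fluorophenyl on a saturated chain carbon bound to a nitrogen on an aromatic ring. Going by the values given here, only one measured step bears on this carbon, a 1.8-fold lower number from compound 1 to compound 2 (0.26 log units; within the scatter), and it changes the group without leaving the scatter. Neither measured compound carries the entering group, so the guidance is thin, and no step beyond the scatter is expected. The expected change is a 1.8-fold lower number from compound 2 to compound 3 (0.26 log units; within the scatter). Compound 3 is estimated at 3000 nM, with an expected range of 700 nM to 12000 nM.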

Compound 3, half-maximal inhibitory concentration: 18000 nM
Estimate against measurement, compound 3: 6.0-fold (0.78 log units) below; the whole stated range lies below it.
By their numbers in this assay, from the lowest: compounds 2, 1 and 3 (each within the scatter of the next, the first and the last beyond it).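

At this saturated chain carbon bound to a nitrogen on an aromatic ring, this assay now shows a change that leaves the scatter: 2-hydroxy-3-methylphenyl in place of 3-chloro-4-fluorophenyl gives (a 3.3-fold higher number from compound 2 to compound 3 (0.51 log units; beyond the scatter)). The same entering group in place of 2-bromophenyl stays within the scatter (a 1.8-fold higher number from compound 1 to compound 3 (0.26 log units; within the scatter)), so how this change reads depends on the group it replaces. No measurement at hand accounts for this difference. The compounds shown leave open whether the hydroxy or the methyl of the entering group carries the step, and how an aminomethyl group or a carboxylic acid on the phenyl ring would read here.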